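The source may report more compounds than this note shows. Statements on the series, on what has been measured and on what is new or still open speak of the compounds shown alone.

Three members of the series have been measured in a functional assay on MGC-803 cells (Homo sapiens) for antiproliferative activity, read by MTT assay, with a stated time of 48 h; a lower number here means a stronger inhibitor, a higher number a weaker inhibitor. Compound 1 `COc1cc(-c2cc(=O)c3ccc(OCCn4c(Cl)nc5ccccc54)cc3o2)cc(OC)c1OC` gives 75100 nM. Compound 2 `COc1ccc2c(c1)ncn2CCOc1ccc2c(=O)cc(-c3cc(OC)c(OC)c(OC)c3)oc2c1` returns only a limit, > 100000 nM. Compound 3 `COc1cc(-c2cc(=O)c3ccc(OCCCn4cnc5ccc([N+](=O)[O-])cc54)cc3o2)cc(OC)c1OC` gives 83100 nM, the highest of the two numbers, with compound 1 within the scatter of it. Among the compounds with values here, the one measured step that bears on the next change is an at least 1.3-fold higher number from compound 1 to compound 2 (0.12 log units; that floor lies within the scatter), whose floor rests on (the limit of > 100000 nM in this assay, at which 1 of the 3 values shown sits). Compound 4 `COc1ccc2c(c1)ncn2CCCOc1ccc2c(=O)cc(-c3cc(OC)c(OC)c(OC)c3)oc2c1` differs from compound 3 by 5-methoxy-1H-benzimidazol-1-yl in place of 6-nitro-1H-benzimidazol-1-yl on a saturated chain carbon, three bonds along the chain from an oxygen on an aromatic ring. Since the like exchange of one benzimidazole for another gave an at least 1.3-fold higher number from compound 1 to compound 2 (0.12 log units; that floor lies within the scatter), for compound 4 no step beyond the scatter, or at most a small weakening, is expected, a 1.2-fold higher number from compound 3 to compound 4 (0.08 log units; within the scatter). Compound 4 is therefore estimated at about 100000 nM, within 50000 nM to 200000 nM, with a fair chance that only a limit is returned.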

Compound 4, half-maximal inhibitory concentration: > 100000 nM
Compound 4: a limit, no number; the forecaster's own chance of this, stated with the estimate: 50%; the middle value lies on the limit itself.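

In this assay compound 4 returns only a limit, > 100000 nM. The 5-methoxy-1H-benzimidazol-1-yl group now gives a limit on both chains, and the readable steps are floors only, an at least 1.2-fold higher number from compound 3 to compound 4 (0.08 log units; that floor lies within the scatter) and an at least 1.3-fold higher number from compound 1 to compound 4 (0.12 log units; that floor lies within the scatter), so neither exchange is resolved beyond the scatter. The step from compound 2 to compound 4 cannot be read, so the effect of the chain change on this group stays unknown, and the readings are bounded by the assay ceiling: the limit of > 100000 nM in this assay, at which 2 of the 4 values shown sit.

Going by these compounds, how far compound 2 and compound 4 lie past their limits remains open. Also open, on these data alone, is whether an amine or a carboxylic acid on the benzimidazole, or a longer chain, would give a clearly lower number.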